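The compounds below may be only part of what the source reports. "The series", "measured", "known", "first", "only" and "open" are said of these compounds alone.

In an assay on cells for inhibition of HSP60/HSP10 (Homo sapiens), with a stated time of 60 min (a higher number here means a weaker inhibitor, a lower number a stronger inhibitor), compound 2 `O=S(=O)(Nc1ccc(-c2nc3ccccc3o2)cc1)c1cccc(O)c1` gives 62000 nM, the highest of the two numbers shown. Compound 3 `O=S(=O)(Nc1ccc(-c2nc3cc(NS(=O)(=O)c4cccc(O)c4)ccc3o2)cc1)c1cccc(O)c1` gives 17000 nM in this assay, so a 3.6-fold lower number from compound 2 to compound 3 (0.56 log units; beyond the scatter). Compound 1 `O=S(=O)(Nc1ccc2oc(-c3ccccc3)nc2c1)c1cccc(C(F)(F)F)c1` reaches only a limit of this assay, > 100000 nM. Compound 4 `O=S(=O)(Nc1ccc(-c2nc3ccccc3o2)cc1)c1ccc(O)cc1` has not yet been measured in this assay. It differs from compound 2 by 4-hydroxyphenyl in place of 3-hydroxyphenyl on a sulfonyl sulfur. Among the measured compounds shown here, the single measured step adds a whole group rather than rearranging one, so it offers no guide to the direction of this change. The step from compound 2 to compound 4 is therefore expected to be a 1.0-fold lower number from compound 2 to compound 4 (0.01 log units; within the scatter), within the scatter. Compound 4 is estimated at 60000 nM in this assay, between 20000 nM and 180000 nM.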

Compound 4, half-maximal inhibitory concentration: 78000 nM
Compound 4: the middle estimate sits 1.3-fold (0.11 log units) below what was measured; low and high end bracket the measured number.
By their numbers in this assay, from the lowest: compound 3; then compounds 2 and 4 (each within the scatter of the next). At a limit, above all of these: compound 1.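

Compound 2 and compound 4 have the same atoms, so this is the only step shown that changes where a group is attached without adding anything: in this assay, 4-hydroxyphenyl in place of 3-hydroxyphenyl on a sulfonyl sulfur gives a 1.3-fold higher number from compound 2 to compound 4 (0.10 log units; within the scatter). This assay therefore does not tell these two hydroxyphenyl groups apart at this position. Neither compound reaches the limit of the assay, though one compound shown does: the limit of > 100000 nM in this assay, at which 1 of the 4 values shown sits.

On these data alone, it remains open whether an amine or a carboxylic acid in place of the hydroxyl would shift the number. As far as these compounds go, it is also open whether 4-hydroxyphenyl would give the same result on the core of compound 3.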